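Aryl ring swap on an aminoimidazopyrazine series

This account rests on a few compounds, and the source may have more. Where it says the series, first, only, none or still open, it means among the compounds named here.

Measured compounds:
- compound 1, `Cc1n[nH]c2ccc(-c3nc4cnc(N5CCC(C)CC5)cn4c3Nc3ccc(Cl)cc3)cc12`: 12.6%
- compound 2, `Cc1n[nH]c2ccc(-c3nc4cnc(N5CCN(C)CC5)cn4c3Nc3ccc(I)cc3)cc12`: "not determined" (no result reported)
- compound 3, `Cc1cc(Br)ccc1Nc1c(-c2ccc3[nH]nc(C)c3c2)nc2cnc(N3CCN(C)CC3)cn12`: "not determined" (no result reported)

In a functional assay on CWR22R cells (Homo sapiens) for inhibition, with a stated time of 120 h, tested at 10 uM (on this read-out higher numbers stand for more inhibition at the one concentration tested (going by the name of the read-out) and lower numbers for less inhibition), compound 1 gives 12.6%. In this assay compound 2 gives "not determined" (no result reported), and compound 3 gives "not determined" (no result reported), so compound 2 cannot be placed against either neighbour on the numbers shown. The unmeasured compound 4, `Cc1n[nH]c2ccc(-c3nc4cnc(N5CCN(C)CC5)cn4c3Nc3ccc(Cl)cc3Cl)cc12`, differs from compound 2 by a single change: 2,4-dichlorophenyl in place of 4-iodophenyl on a nitrogen on an aromatic ring. Among the measured compounds shown here, with no measured step available for this pair, the expected step from compound 2 to compound 4 in this assay is taken as none beyond the scatter, in no set direction. On that basis compound 4 is estimated to give 15% in this assay, with a range from 0% to 40%.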

Compound 4, a percentage reported as inhibition, at one concentration (the size of the read-out at that concentration, not a potency): 9.53%
For compound 4 the middle estimate is 5.5 percentage points above the measured one; low and high end bracket the measured number.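

In this assay, among the compounds shown here, compound 2 has no number, and no step to compound 4 can be read. The compounds shown leave open how swapping the aryl group affects inhibition, and no further evidence bears on this result.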